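The compounds below may be only part of what the source reports. "The series", "measured", "known", "first", "only" and "open" are said of these compounds alone.

Compound 3 `O=C(NO)c1ccc(NCc2nc(-c3ccc(Cl)c(Cl)c3)nn2-c2ccccc2)cc1` gives 34.5% in an assay on Sf9 cells for inhibition of protein deacetylase HDAC6 (Homo sapiens), read by fluorescence, with a stated time of 40 min, tested at 100 nM (a higher number here means more inhibition at the concentration tested (going by the name of the read-out), a lower number less inhibition), and stands lowest of the three measured analogues: compound 1 `O=C(NO)c1ccc(NCc2nc(-c3cccnc3)nn2-c2ccccc2)cc1` gives 57.7% and compound 2 `O=C(NO)c1ccc(NCc2nc(-c3ccc(Cl)cc3)nn2-c2ccccc2)cc1` gives 67.2%. Compound 4 `O=C(NO)c1ccc(NCc2nc(-c3ccc(C(F)(F)F)cc3)nn2-c2ccccc2)cc1` follows from compound 3 by 4-(trifluoromethyl)phenyl in place of 3,4-dichlorophenyl on an aromatic carbon. Going by the values given here, two measured steps bear on it. The step of a number 32.7 percentage points lower from compound 2 to compound 3 (beyond the scatter) shows that adding the second chloro cost most of the inhibition, and the step of a number 23.2 percentage points lower from compound 1 to compound 3 (beyond the scatter) points the same way, while a number 9.5 percentage points higher from compound 1 to compound 2 (within the scatter) places a single para group at the upper end of the set. Removing the second chloro and returning to a single para group is therefore expected to recover inhibition, a step of a number 25.5 percentage points higher from compound 3 to compound 4 (beyond the scatter) upward for compound 4. Compound 4 is estimated at 60%, within 42% to 78%.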

Compound 4, a percentage reported as inhibition, at one concentration (the size of the read-out at that concentration, not a potency): 41.6%
The estimate for compound 4 lay 18.4 percentage points above the measured number; measured number outside the range, below it.
By their numbers in this assay, from the lowest: compounds 3 and 4 (each within the scatter of the next); then compounds 1 and 2 (each within the scatter of the next).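

In this assay, a single substituent on the phenyl ring does not by itself secure the higher reading: trifluoromethyl in place of chloro gives a number 25.6 percentage points lower from compound 2 to compound 4 (beyond the scatter). 4-(Trifluoromethyl)phenyl in place of 3,4-dichlorophenyl gives only a number 7.1 percentage points higher from compound 3 to compound 4 (within the scatter), and in place of pyridin-3-yl it gives a number 16.1 percentage points lower from compound 1 to compound 4 (beyond the scatter), so the identity of the group at this position matters, not just the number of groups on the ring. No measurement shown here explains these steps. As far as these compounds go, how a 4-aminophenyl or 4-carboxyphenyl group would read at this position remains open.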